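Acetylating a further hydroxy group in an inactive-range series

A few compounds are considered here, and "the series" means these few. Any claim that something is new, unique, unknown or untested is made for them only; others in the source may bear on it.

In a functional assay on P388 cells (Mus musculus) for cytotoxicity (a higher number here means a weaker inhibitor, a lower number a stronger inhibitor), compound 1 (`C=C/C=C\[C@H](C)[C@H](OC(N)=O)[C@@H](C)[C@H](OC(C)=O)[C@@H](C)C/C(C)=C\[C@H](C)[C@@H](O)[C@@H](C)/C=C\[C@@H](O)C[C@@H]1OC(=O)C(C)=C[C@H]1C`) gives > 8100 nM, which is a limit. Compound 2 (`C=C/C=C\[C@H](C)[C@H](OC(N)=O)[C@@H](C)[C@H](OC(C)=O)[C@@H](C)C/C(C)=C\[C@H](C)[C@@H](OC(C)=O)[C@@H](C)/C=C\[C@@H](O)C[C@@H]1OC(=O)C(C)=C[C@H]1C`) gives > 7580 nM, which is also a limit. Within the data shown here, compound 2 therefore has no numeric reading, and the only other value available to place it against is a limit too.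

Compound 3 (`C=C/C=C\[C@H](C)[C@H](OC(N)=O)[C@@H](C)[C@H](OC(C)=O)[C@@H](C)C/C(C)=C\[C@H](C)[C@@H](OC(C)=O)[C@@H](C)/C=C\[C@H](C[C@@H]1OC(=O)C(C)=C[C@H]1C)OC(C)=O`) differs from compound 2 by acetyl in place of hydrogen on an oxygen on a saturated carbon, a change from hydroxy to acetoxy.

Among the measured compounds shown here, the one measured step that bears on this is the same kind of exchange made elsewhere on the molecule: a step that the two limits leave unreadable from compound 1 to compound 2. It gives neither a size nor a direction, so it offers only weak precedent. It shows that one such acetylation produced no numeric reading, and nothing measured points to a gain in potency. No step beyond the usual scatter is therefore expected in this assay, and compound 3 will probably also be reported only as a limit.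

The expected change is an at least 1.0-fold lower number from compound 2 to compound 3 (0.02 log units; that floor lies within the scatter). Compound 3 is estimated at 7100 nM, with an expected range of 3000 nM to 15000 nM.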

Compound 3, half-maximal inhibitory concentration: 7080 nM
Compound 3: the middle estimate sits 1.0-fold (0.00 log units) above what was measured; the range from low to high includes it.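

In this assay, hydroxy to acetoxy on this oxygen on a saturated carbon gives an at least 1.0-fold lower number from compound 2 to compound 3 (0.02 log units; that floor lies within the scatter), so the result supports no gain beyond the scatter. Compound 3 is the only one of the three compounds shown with a numeric reading, which makes this the only step in the series with any readable size, since the earlier step cannot be read. That reading is only a floor, as one side of the comparison is a limit: the limit of > 7580 nM in this assay, at which 1 of the 3 values shown sits.

The true distance between compound 2 and compound 3 stays open, as does whether acetyl at this place would read the same with a free hydroxy at the other acetylated oxygen, a comparison the compounds shown do not offer. Also open, from the compounds shown here alone, is whether a longer acyl chain such as butanoyl on this oxygen, or an amine in place of the oxygen, would move the number beyond the scatter in this assay.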